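Hydroxyphenyl for methylphenyl on a prostacyclin synthase inhibitor

The source may hold more compounds than are shown below. What is called first, only, known or untested is meant among the compounds shown, and "the series" means these compounds.

Compound 1, `CC(C)(Oc1ccc(F)cc1)C1OCC(C/C=C\CCC(=O)O)C(c2cccnc2)O1`, in an assay for inhibition of prostacyclin synthase (Homo sapiens), using microsomes (a lower number here means a stronger inhibitor, a higher number a weaker inhibitor), gives 2000 nM.
Compound 2, `Cc1ccc(OC(C)(C)C2OCC(C/C=C\CCC(=O)O)C(c3cccnc3)O2)cc1`, in this assay gives 25000 nM.

Among the compounds with values here, compound 2 stands with the highest number of the two measured compounds; the nearest is compound 1, and the single step that separates them, methyl in place of fluoro on an aromatic carbon, reads a 13-fold higher number from compound 1 to compound 2 (1.10 log units; beyond the scatter).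

Compound 3, `CC(C)(Oc1ccccc1O)C1OCC(C/C=C\CCC(=O)O)C(c2cccnc2)O1`, has not yet been measured. It differs from compound 2 in one place: 2-hydroxyphenyl in place of 4-methylphenyl on an oxygen on a saturated carbon, that carbon also carrying a saturated chain carbon. Within the data shown here, the only measured step, from compound 1 to compound 2, shows that exchanging a group on that aromatic ring can move the number by a large amount, but it ran from fluoro to methyl and says nothing direct about a hydroxyl. That step is taken as a sign that the ring substituent matters and that a return toward the number of compound 1 is as plausible as no change. Compound 3 is therefore expected to show a step of a 4.2-fold lower number from compound 2 to compound 3 (0.62 log units; beyond the scatter), with an estimate of 6000 nM, in a range from 1200 nM to 40000 nM.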

Compound 3, half-maximal inhibitory concentration: > 100000 nM
Compound 3: no number, only a limit; the forecaster's own chance of this, stated with the estimate: 5%; middle value at least 16-fold (1.22 log units) away from the limit.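

In this assay compound 3 gives > 100000 nM, which is a limit and not a number, so its place can be read in one direction only: the limit of > 100000 nM in this assay, at which 1 of the 3 values shown sits.

Even so, the steps are clear in that direction: 2-hydroxyphenyl in place of 4-methylphenyl gives an at least 4.0-fold higher number from compound 2 to compound 3 (0.60 log units; beyond the scatter), and 2-hydroxyphenyl in place of 4-fluorophenyl gives an at least 50-fold higher number from compound 1 to compound 3 (1.69 log units; beyond the scatter). The earlier pair showed only that exchanging fluoro for methyl on a 4-substituted phenyl group moves the number, whereas compound 3 shows that the 2-hydroxyphenyl group, the only one of the three with a hydroxyl, does not bring the number back toward that of compound 1 but carries it past both other compounds.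

The 2-hydroxyphenyl group differs from the other two groups both in the kind of substituent and in its name position on the ring, and the compounds shown do not separate these two changes, which a 4-hydroxyphenyl group could begin to do. From the compounds shown here alone, how far the true number of compound 3 lies past its limit stays open, as does whether a methoxy group or an amine on that ring would give a similar result.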